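Series notes: amino variation on the shared core

The compounds below may be only part of what the source reports. "The series", "measured", "known", "first", "only" and "open" are said of these compounds alone.

Three compounds of the shared core carry a measurement so far. Compound 1 `CCCN(CC1CC1)c1nc(C)nc2c(-c3ccc(OC)cc3C)c(C)nn12` gives 1.96 nM in an assay on cell membranes for displacement of a labelled ligand from corticotropin-releasing factor receptor 1 (Rattus norvegicus); a higher number here means a weaker inhibitor, a lower number a stronger inhibitor. Compound 2 `CCC(CC)Nc1nc(C)nc2c(-c3cc(OC)c(OC)cc3Br)c(C)nn12` gives 6.08 nM in this assay. Compound 3 `CCN(CC)c1nc(C)nc2c(-c3c(C)cc(OC)cc3OC)c(C)nn12` gives 1.2 nM in this assay. Compound 3 and compound 1 lie within the scatter of each other; compound 2 stands beyond the scatter with the higher number. For the measured compounds named here, no pair of measured compounds differs in a single place, so no measured step is available.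

Compound 4 `CCC(CC)Nc1nc(C)nc2c(-c3c(C)cc(OC)cc3OC)c(C)nn12` is the next structure to be measured. It differs from compound 3 by (pentan-3-yl)amino in place of diethylamino on an aromatic carbon. Compound 2 also carries the (pentan-3-yl)amino group, but on a different aryl, so its value shows nothing about this change alone.

For this change the step from compound 3 to compound 4 is expected to be small, at most a modest weakening, and is estimated at a 1.7-fold higher number from compound 3 to compound 4 (0.22 log units; within the scatter). Compound 4 is therefore expected to give about 2 nM in this assay, within a range of 0.7 nM to 6 nM.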

Compound 4, half-maximal inhibitory concentration: 5 nM
Beside the measured number, compound 4's estimate is 2.5-fold (0.40 log units) below it; low and high end bracket the measured number.
By their numbers in this assay, from the lowest: compounds 3 and 1 (each within the scatter of the next); then compounds 4 and 2 (each within the scatter of the next).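

For the compounds shown here, with the aryl group of compound 3 held fixed, placing (pentan-3-yl)amino in place of diethylamino on the aromatic carbon between two ring nitrogen atoms gives a 4.2-fold higher number from compound 3 to compound 4 (0.62 log units; beyond the scatter) in this assay, the first measured step at this position. The change therefore has a readable cost here, which compound 2 could not show on its different aryl group. The entering group carries a hydrogen-bond donor and the leaving group none, but no available data give a reason for the step.

Going by these compounds, whether the step comes from that donor or from the larger alkyl group remains open, and methyl(pentan-3-yl)amino on the aryl group of compound 3 would separate the two. On these data alone, whether the same step holds on the aryl groups of compound 1 or compound 2 also remains open.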